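From Iodo to Tert-Butyl on the Shared Core

The source may report more compounds than this note shows. Statements on the series, on what has been measured and on what is new or still open speak of the compounds shown alone.

Compound 1 `O=C(CCc1cccc2c1B(O)OC2)Nc1ccccc1`: 30000 nM
Compound 2 `O=C(CCc1cccc2c1B(O)OC2)Nc1ccc(I)cc1`: 49000 nM

Both values come from an ADME assay on WI-38 cells (Homo sapiens) for cytotoxicity, read by MTT assay, with a stated time of 72 h; on this read-out lower numbers stand for stronger inhibition and higher numbers for weaker inhibition. Compound 2, at 49000 nM, stands within the scatter of compound 1. Compound 3 `CC(C)(C)c1ccc(NC(=O)CCc2cccc3c2B(O)OC3)cc1` has tert-butyl in place of iodo on an aromatic carbon. Among the measured compounds shown here, only one measured step bears on that carbon, a 1.6-fold higher number from compound 1 to compound 2 (0.21 log units; within the scatter). It offers no ground for expecting a change beyond the scatter in this assay. The expected step is a 1.2-fold lower number from compound 2 to compound 3 (0.09 log units; within the scatter). Compound 3 is estimated at 40000 nM, with an expected range of 20000 nM to 80000 nM.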

Compound 3, half-maximal inhibitory concentration: 55000 nM
Compound 3: the middle estimate sits 1.4-fold (0.14 log units) below what was measured; low and high end bracket the measured number.
By their numbers in this assay, from the lowest: compounds 1, 2 and 3 (each within the scatter of the next).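

In this assay, tert-butyl in place of iodo gives a 1.1-fold higher number from compound 2 to compound 3 (0.05 log units; within the scatter), and tert-butyl in place of hydrogen gives a 1.8-fold higher number from compound 1 to compound 3 (0.26 log units; within the scatter), both within the scatter. This carbon, on a six-membered aromatic ring of carbon only, has thus taken a group of 4 heavy atoms as well as iodo without any step beyond the scatter. No measurement at hand gives a reason for this. As far as these compounds go, whether an amine or a carboxylic acid on this carbon would move the number beyond the scatter stays open, and so does the outcome with a longer chain there.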